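Swapping the aryl amide for a thiophene

The source may hold more compounds than are shown below. What is called first, only, known or untested is meant among the compounds shown, and "the series" means these compounds.

Compound 1 `N#Cc1cccc(C(=O)NC(=S)N2CCc3c(OCCCCCOc4ccc(Cl)cc4)cccc32)c1`: 9750 nM
Compound 2 `CN(C)c1ccc(C(=O)NC(=S)N2CCc3c(OCCCCCOc4ccc(Cl)cc4)cccc32)cc1`: > 50000 nM

Both compounds share one core and differ only in the group attached to the carbonyl carbon. In an ADME assay on Huh-7 cells (Homo sapiens) for cytotoxicity (a higher number here means that more compound is tolerated, a lower number that less compound is tolerated), compound 1 gives 9750 nM. For compound 2 the assay reports only a limit, > 50000 nM, so its true value is not known as a number. The change from compound 1 to compound 2 moved the read-out by an at least 5.1-fold higher number from compound 1 to compound 2 (0.70 log units; beyond the scatter), placing compound 2 at the upper edge of what the assay can report, that is at the limit of > 50000 nM in this assay, at which 1 of the 2 values shown sits.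

Compound 3 `O=C(NC(=S)N1CCc2c(OCCCCCOc3ccc(Cl)cc3)cccc21)c1cccs1` carries thiophen-2-yl in place of 4-(dimethylamino)phenyl on a carbonyl carbon. Going by the values given here, only one measured step touches this position, and it was at least modest in size. The incoming group is unlike either of the two measured groups, so the direction of the new step cannot be read from that step alone; the numbers could fall back toward those of compound 1 or stay at the limit.

For compound 3 the expected result in this assay is 25000 nM, within 8000 nM to 70000 nM. The estimated step is an at least 2.0-fold lower number from compound 2 to compound 3 (0.30 log units; that floor lies within the scatter).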

Compound 3, half-maximal cytotoxic concentration: 10700 nM
For compound 3 the middle estimate is 2.3-fold (0.37 log units) above the measured one, within the range that was stated.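

In this assay, thiophen-2-yl on the carbonyl carbon gives an at least 4.6-fold lower number from compound 2 to compound 3 (0.66 log units; beyond the scatter), so the high tolerance seen with 4-(dimethylamino)phenyl does not carry over to every ring at this position. Set against the 3-cyanophenyl group, the same five-membered ring gives a 1.1-fold higher number from compound 1 to compound 3 (0.04 log units; within the scatter), so this read-out does not separate these two quite different groups, even though one ring has five members and the other six. Of the three compounds, only compound 2 reaches a limit rather than a number: the limit of > 50000 nM in this assay, at which 1 of the 3 values shown sits.

From the compounds shown here alone, what remains open is whether the dimethylamino group itself sets compound 2 apart, or whether the phenyl ring carrying it also plays a part; a plain phenyl group, or a phenyl ring bearing a morpholine or a primary amine in place of the dimethylamino group, would help tell these apart. Going by these compounds, since the value for compound 2 is only a limit, the true size of its gap from the other two compounds also stays unknown.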